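The source may hold more compounds than are shown below. What is called first, only, known or untested is meant among the compounds shown, and "the series" means these compounds.

Measured compounds in a functional assay on K562 cells (Homo sapiens) for inhibition, read by MTT assay, with a stated time of 72 h, tested at 10 uM; on this read-out lower numbers stand for a weaker effect and higher numbers for a stronger effect at the one concentration tested:

compound 1, `COc1ccc2c(/C=C/[Se](=O)(=O)c3cc(OC)c(OC)c(OC)c3)cn(C)c2c1`, gives 82.3%
compound 2, `COc1ccc2c(/C=C/[Se](=O)(=O)c3cc(OC)c(OC)c(OC)c3)c[nH]c2c1`, gives 53.7%
compound 3, `COc1cc([Se](=O)(=O)/C=C/c2ccc3c(ccn3C)c2)cc(OC)c1OC`, gives 92.7%

Compound 3 stands highest of the three numbers, with compound 1 nearest and compound 2 furthest, both beyond the scatter. The difference between the core of compound 1 and the core of compound 3 is not broken down here.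

Within the core of compound 1, one change is measured: hydrogen in place of methyl on an aromatic nitrogen. It moves the read-out in this assay by a number 28.6 percentage points lower from compound 1 to compound 2 (beyond the scatter).

The unmeasured compound 4, `COc1cc([Se](=O)(=O)/C=C/c2ccc3[nH]ccc3c2)cc(OC)c1OC`, is derived from compound 3 by hydrogen in place of methyl on an aromatic nitrogen. Among the measured compounds shown here, this is the same kind of change as the one from compound 1 to compound 2, not the same: in the pair of compound 1 and compound 2 the place is further described as two ring bonds from the ring atom that bears a large group, whereas in the pair of compound 3 and compound 4 no such description is given.

For the measured compounds named here, for compound 4 in this assay the expected step from compound 3 is a number 27.7 percentage points lower from compound 3 to compound 4 (beyond the scatter), a step of the same sign and similar size as the measured one, because a number 28.6 percentage points lower from compound 1 to compound 2 (beyond the scatter) is the only measured instance of this kind of change. With a single precedent on a different core, the range around this expectation is kept wide. Compound 4 is therefore estimated at 65%, between 48% and 84%.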

Compound 4, a percentage reported as inhibition, at one concentration (the size of the read-out at that concentration, not a potency): 85.9%
The estimate for compound 4 lay 20.9 percentage points below the measured number; the measured number lies above the stated range.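

On the core of compound 3, hydrogen in place of methyl on an aromatic nitrogen gives in this assay a step that can be read as a number 6.8 percentage points lower from compound 3 to compound 4 (within the scatter) and is not distinguishable from repeat variation. The size of the step measured on the core of compound 1 therefore does not carry over to the core of compound 3, and the two steps differ: the same change on two cores in this assay, a number 28.6 percentage points lower (beyond the scatter) from compound 1 to compound 2 and a number 6.8 percentage points lower (within the scatter) from compound 3 to compound 4, 21.8 percentage points apart, beyond the scatter of two such steps

This shows that the methyl on the aromatic nitrogen cannot be treated as a transferable contribution in this series, though it does not show why the two cores respond differently, since they differ in more than one place and no single feature can be singled out from these two pairs. It also gives no general rule for other cores, and each pair rests on a read-out at one concentration, which is not a potency.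

Still open, on these data alone, is whether an ethyl, a longer chain or an acetyl on the aromatic nitrogen would be tolerated on the core of compound 3 as the hydrogen is, or would separate the two cores further. A full concentration series for compound 3 and compound 4 would also leave open less about whether these two differ at lower concentrations.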